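The source may report more compounds than this note shows. Statements on the series, on what has been measured and on what is new or still open speak of the compounds shown alone.

Compound 1 `CCCN1CC(=O)N(Cc2ccc(C(=O)NO)cc2)C1=O`: 53.4 nM
Compound 2 `Cc1ccc(CN2CC(=O)N(Cc3ccc(C(=O)NO)cc3)C2=O)cc1`: 17.6 nM
Compound 3 `CC1(c2ccccc2)NC(=O)N(Cc2ccc(C(=O)NO)cc2)C1=O`: 74.9 nM

In an assay on isolated protein for inhibition of protein deacetylase HDAC6 (Homo sapiens), read by fluorescence, with stated times of 10 min and 2 h (on this read-out lower numbers stand for stronger inhibition and higher numbers for weaker inhibition), compound 3 stands highest of the three numbers; the gap to compound 1 lies within the scatter, the gap to compound 2 beyond it. Compound 4 `O=C(NO)c1ccc(CN2C(=O)NC(Cc3ccccc3)(c3ccccc3)C2=O)cc1` differs from compound 3 by phenyl in place of hydrogen on a saturated chain carbon bound to a saturated ring carbon, the same difference cut one bond further out reading methyl to benzyl. Among the compounds with values here, the only measured step, a 3.0-fold lower number from compound 1 to compound 2 (0.48 log units; beyond the scatter), adds an aromatic ring at a different place, on a chain carbon bound to the ring nitrogen rather than on the ring carbon, so it bears on the change only loosely. Taken as a rough guide, it points to a small lowering of the number. For compound 4 the expected step is a 1.7-fold lower number from compound 3 to compound 4 (0.22 log units; within the scatter), giving an estimate of 45 nM with a range from 18 nM to 120 nM.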

Compound 4, half-maximal inhibitory concentration: 71.9 nM
The estimate for compound 4 lay 1.6-fold (0.20 log units) below the measured number; the range from low to high includes it.
By their numbers in this assay, from the lowest: compound 2; then compounds 1, 4 and 3 (each within the scatter of the next).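

Phenyl in place of hydrogen on a saturated chain carbon bound to a saturated ring carbon gives a 1.0-fold lower number from compound 3 to compound 4 (0.02 log units; within the scatter) in this assay, so this position takes the added aromatic ring with no change beyond the scatter. The earlier step, a 3.0-fold lower number from compound 1 to compound 2 (0.48 log units; beyond the scatter), at a different place, does not carry over to this carbon. No measurement available here accounts for the flat step.

From the compounds shown here alone, whether an amine or a carboxylic acid on the added phenyl would move the number stays open. So does the effect of a longer chain in place of benzyl.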